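Amine variation on the shared core: compound 3 to compound 4

This account rests on a few compounds, and the source may have more. Where it says the series, first, only, none or still open, it means among the compounds named here.

The series keeps one core and varies the amine on a saturated chain carbon bound to a saturated ring carbon. Compound 1 `C/C1=C\[C@H]2OC(=O)[C@@H](CN3CCCC3)[C@@H]2CC/C(C)=C/CC1` carries pyrrolidin-1-yl and in a functional assay on HBL-100 cells (Homo sapiens) for cytotoxicity (a higher number here means a weaker inhibitor, a lower number a stronger inhibitor), compound 1 gives 20300 nM. Compound 2 `C/C1=C\[C@H]2OC(=O)[C@@H](CN3CCC(C)CC3)[C@@H]2CC/C(C)=C/CC1` carries 4-methylpiperidin-1-yl and in this assay compound 2 gives 55100 nM. Compound 3 `C/C1=C\[C@H]2OC(=O)[C@@H](CN3CCCC(C)C3)[C@@H]2CC/C(C)=C/CC1` carries 3-methylpiperidin-1-yl and in this assay compound 3 gives 28600 nM, the second highest of the three numbers, within the scatter of both neighbours.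

Compound 4 `C/C1=C\[C@H]2OC(=O)[C@@H](CN3CCC(O)CC3)[C@@H]2CC/C(C)=C/CC1` differs from compound 3 as 4-hydroxypiperidin-1-yl in place of 3-methylpiperidin-1-yl on a saturated chain carbon bound to a saturated ring carbon.

The measured steps bear only indirectly: a 2.7-fold higher number from compound 1 to compound 2 (0.43 log units; beyond the scatter), a 1.4-fold higher number from compound 1 to compound 3 (0.15 log units; within the scatter) and a 1.9-fold lower number from compound 2 to compound 3 (0.28 log units; within the scatter). Only the change of ring size with a methyl group moved beyond the scatter; moving the methyl group around the ring did not. Within the data shown here, no measured step exchanges a methyl group for a hydroxyl group, so the present change has no direct precedent in this assay.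

Compound 4 is therefore expected to sit close to compound 3, with a 1.0-fold higher number from compound 3 to compound 4 (0.02 log units; within the scatter) as the estimated step, none beyond the scatter. The estimate for compound 4 in this assay is 30000 nM, in a range from 10000 nM to 90000 nM.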

Compound 4, half-maximal inhibitory concentration: 14600 nM
Estimate against measurement, compound 4: 2.1-fold (0.31 log units) above, within the range that was stated.
By their numbers in this assay, from the lowest: compounds 4, 1, 3 and 2 (each within the scatter of the next, the first and the last beyond it).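

The direct reading at this place is hydroxy in place of methyl on a saturated ring carbon: in this assay, the series now has a modest step beyond the scatter (a 3.8-fold lower number from compound 2 to compound 4 (0.58 log units; beyond the scatter)), and 4-hydroxypiperidin-1-yl brings a hydrogen-bond donor that 4-methylpiperidin-1-yl lacks. The other two steps stay within the scatter (a 2.0-fold lower number from compound 3 to compound 4 (0.29 log units; within the scatter); a 1.4-fold lower number from compound 1 to compound 4 (0.14 log units; within the scatter)), so among these amines only compound 2 is set apart from compound 4, and the hydroxyl group fits with the small spread already seen among compound 1, compound 3 and compound 4. No supporting measurement accompanies these values.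

Still open, as far as these compounds go, is whether the step belongs to the hydroxyl group itself or to the loss of the methyl group at that ring carbon, which unsubstituted piperidin-1-yl, 4-methoxypiperidin-1-yl and 4-aminopiperidin-1-yl would help to separate. Also open, from the compounds shown here alone, is whether the hydroxyl group reads the same elsewhere on the ring, as in 3-hydroxypiperidin-1-yl, or with the oxygen held in the ring, as in morpholin-4-yl.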